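The source may hold more compounds than are shown below. What is called first, only, known or untested is meant among the compounds shown, and "the series" means these compounds.

Three compounds share one core and differ only at the oxygen next to the carbonyl group. Compound 1 `CC(C)(C(=O)O)C(c1ccc(Nc2ccc3ccccc3c2)cc1)n1ccnc1` carries a hydrogen there, and in an assay on isolated protein for inhibition of cytochrome P450 26A1 (Homo sapiens), read by scintillation counting (on this read-out lower numbers stand for stronger inhibition and higher numbers for weaker inhibition), compound 1 gives 300 nM. Compound 2 `CCOC(=O)C(C)(C)C(c1ccc(Nc2ccc3ccccc3c2)cc1)n1ccnc1` carries an ethyl, and in this assay compound 2 gives 0.35 nM, so that the step of an 860-fold lower number from compound 1 to compound 2 (2.93 log units; beyond the scatter) is large. Compound 3 `CCCCOC(=O)C(C)(C)C(c1ccc(Nc2ccc3ccccc3c2)cc1)n1ccnc1` carries a butyl, and in this assay compound 3 gives 200 nM. Among the three numbers compound 3 stands second highest: its number lies close to that of compound 1, as a 1.5-fold lower number from compound 1 to compound 3 (0.18 log units; within the scatter) shows, while against compound 2 the step of a 570-fold higher number from compound 2 to compound 3 (2.76 log units; beyond the scatter) is large.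

Compound 4 `CCCCCOC(=O)C(C)(C)C(c1ccc(Nc2ccc3ccccc3c2)cc1)n1ccnc1` is not yet measured. It differs from compound 3 by methyl in place of hydrogen on a saturated chain carbon, four bonds along the chain from an oxygen next to a carbonyl group. Going by the values given here, the one measured step that bears on this change is a 570-fold higher number from compound 2 to compound 3 (2.76 log units; beyond the scatter), where lengthening the chain raised the number greatly, and compound 1 together with compound 3 shows that both the shortest and the longest chain so far sit far from compound 2. One further carbon on the chain is therefore expected to leave the number high or to raise it a little. For compound 4 the expected step is a 1.8-fold higher number from compound 3 to compound 4 (0.24 log units; within the scatter). For compound 4 the estimate in this assay is 350 nM, with a range from 100 nM to 1200 nM.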

Compound 4, half-maximal inhibitory concentration: 140 nM
Beside the measured number, compound 4's estimate is 2.5-fold (0.40 log units) above it, within the range that was stated.
By their numbers in this assay, from the lowest: compound 2; then compounds 4, 3 and 1 (each within the scatter of the next, the first and the last beyond it).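

In this assay, methyl in place of hydrogen at the far end of the butyl chain leaves the number where it was, with a 1.4-fold lower number from compound 3 to compound 4 (0.15 log units; within the scatter), so the large rise seen on going from ethyl to butyl does not carry on from butyl to pentyl. The pentyl chain remains far from the ethyl group, at a 400-fold higher number from compound 2 to compound 4 (2.60 log units; beyond the scatter), yet it stands only modestly apart from the hydrogen on this oxygen, at a 2.1-fold lower number from compound 1 to compound 4 (0.33 log units; beyond the scatter), which leaves ethyl as the only group among the four shown with a number far below the others. Nothing available here explains why ethyl stands apart from the butyl and pentyl chains.

The compounds shown leave open how the number behaves between ethyl and butyl, where a propyl chain would sit, and whether a methyl on this oxygen would share the low number of compound 2. They also leave open whether a longer chain such as hexyl, a branched isopropyl group, or an amide in place of the ester would stay near the butyl and pentyl compounds or move away from them.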